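Trifluoromethyl to hydroxy on the anilino ring of compound 2

This account rests on a few compounds, and the source may have more. Where it says the series, first, only, none or still open, it means among the compounds named here.

Of the compounds shown here, two sharing one core have been measured. Compound 1 `COc1cc(/C=C/c2nc(NC3CC3)c3sccc3n2)cc(OC)c1OC` gives 2360000 nM in an ADME assay on L02 cells (Homo sapiens) for cytotoxicity, read by MTT assay; a higher number here means a weaker inhibitor, a lower number a stronger inhibitor. Among the compounds with values here, compound 2 `COc1cc(/C=C/c2nc(Nc3ccc(C(F)(F)F)cc3)c3sccc3n2)cc(OC)c1OC` gives 436000 nM in this assay and so stands as the lower of the two numbers, the only other value being that of compound 1, reached by a 5.4-fold lower number from compound 1 to compound 2 (0.73 log units; beyond the scatter).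

Compound 3 `COc1cc(/C=C/c2nc(Nc3ccc(O)cc3)c3sccc3n2)cc(OC)c1OC` has not yet been measured in this assay. It differs from compound 2 by hydroxy in place of trifluoromethyl on an aromatic carbon; the change sits on an aromatic carbon of a six-membered aromatic ring of carbon only, para to a large group. Within the data shown here, no measured step swaps one substituent on this ring for another: the single step known, a 5.4-fold lower number from compound 1 to compound 2 (0.73 log units; beyond the scatter), exchanges the whole cyclopropyl for the 4-(trifluoromethyl)phenyl, and it only shows that a phenyl on that nitrogen lowers the number. Since compound 3 keeps the phenyl, it is expected to stay nearer to compound 2 than to compound 1, with a step of a 1.7-fold higher number from compound 2 to compound 3 (0.24 log units; within the scatter), most likely upward, and a wide band. Compound 3 is therefore estimated at 750000 nM, between 250000 nM and 2200000 nM.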

Compound 3, half-maximal inhibitory concentration: 2300000 nM
Estimate against measurement, compound 3: 3.1-fold (0.49 log units) below; the whole stated range lies below it.
By their numbers in this assay, from the lowest: compound 2; then compounds 3 and 1 (each within the scatter of the next).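

The hydroxy swap shows that the phenyl on that nitrogen does not lower the number by itself: in this assay, replacing trifluoromethyl with hydroxy on the aromatic carbon gives a 5.3-fold higher number from compound 2 to compound 3 (0.72 log units; beyond the scatter) and takes away the advantage that compound 2 held over compound 1. The comparison with the cyclopropyl compound gives a 1.0-fold lower number from compound 1 to compound 3 (0.01 log units; within the scatter), so 4-hydroxyphenyl and cyclopropyl on that nitrogen cannot be told apart in this assay, and the low number of compound 2 belongs to 4-(trifluoromethyl)phenyl rather than to any phenyl at this place. No measurement in hand accounts for the difference between trifluoromethyl and hydroxy.

With only two substituents on this ring, the compounds shown do not say whether a chlorine, a nitrile, a methoxy or an amine at the same carbon would side with compound 2 or with compound 3. They also leave open whether a bare phenyl, with hydrogen at that carbon, would sit with either of them, and so whether trifluoromethyl lowers the number or hydroxy raises it.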